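Replacing the Acid: From Limit to Measurable Inhibition

The source may report more compounds than this note shows. Statements on the series, on what has been measured and on what is new or still open speak of the compounds shown alone.

Measured so far:
compound 1, `O=C(O)c1ccccc1COc1ccc(OCCOCCNC2CCCC2)cc1`, in a functional assay on SK-OV-3 cells (Homo sapiens) for inhibition, read by CCK-8 assay, with a stated time of 70 h (a lower number here means a stronger inhibitor, a higher number a weaker inhibitor), compound 1 gives > 100000 nM.
compound 2, `Clc1ccc(COc2ccc(OCCOCCNC3CCCCC3)cc2)cc1`, in this assay compound 2 gives 2650 nM.

The value of compound 1 is a limit of this assay, not a number, and the compound stands at the limit of > 100000 nM in this assay, at which 1 of the 2 values shown sits. Among the compounds with values here, compound 2, which carries a different benzyl group and a different ring on the amine, gives a measurable number in this assay, so no step between the two measured compounds can be counted.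

Compound 3, `Cc1ccc(COc2ccc(OCCOCCNC3CCCC3)cc2)cc1`, differs from compound 1 as follows: 4-methylphenyl in place of 2-carboxyphenyl on a saturated chain carbon bound to an oxygen on an aromatic ring. Within the data shown here, no measured step describes this change, so its size is uncertain; a large step toward stronger inhibition is expected, since compound 2, also lacking the acid, gives 2650 nM. Compound 3 is therefore expected to reach 4000 nM, with a range from 1200 nM to 20000 nM. This estimate corresponds to an expected step of an at least 25-fold lower number from compound 1 to compound 3 (1.39 log units; beyond the scatter).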

Compound 3, half-maximal inhibitory concentration: 17200 nM
For compound 3 the middle estimate is 4.3-fold (0.63 log units) below the measured one; low and high end bracket the measured number.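

Taking out 2-carboxyphenyl and putting 4-methylphenyl on a saturated chain carbon bound to an oxygen on an aromatic ring gives, in this assay, an at least 5.8-fold lower number from compound 1 to compound 3 (0.76 log units; beyond the scatter). Within the data shown here, compound 2 differs from compound 1 in two places, so this is the first change at this position that can be read on its own, and it shows that a single swap here moves the series from a limit to a measurable number. The true size of the step stays unknown because the value of compound 1 is a limit and the step is only a bound: the limit of > 100000 nM in this assay, at which 1 of the 3 values shown sits.

The compounds shown do not separate the loss of the carboxylic acid from the gain of the methyl, which an unsubstituted phenyl at this place would do. Steps involving compound 2 cannot be read, since it differs from compound 1 and compound 3 in two places.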